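This account rests on a few compounds, and the source may have more. Where it says the series, first, only, none or still open, it means among the compounds named here.

In a functional assay on Bel-7402 cells (Homo sapiens) for inhibition, read by MTT assay, with a stated time of 24 h, tested at 0.1 ug/mL (a higher number here means more inhibition of growth at the concentration tested, a lower number less inhibition of growth), compound 1 `O=C(CCCCC(S)CCS)Nc1ccccc1` gives 0.85% while compound 2 `O=C(CCCCC(S)CCS)Nc1cccc(Cl)c1` gives 3.09% and compound 3 `O=C(CCCCC(S)CCS)Nc1cccc(C(F)(F)F)c1` gives 2.85% on the same scale. All three numbers lie within the usual scatter of one another, so compound 3 cannot be separated from either of the other two. Going by the values given here, compound 4 `Cc1cccc(NC(=O)CCCCC(S)CCS)c1` keeps the shared core and has methyl in place of trifluoromethyl on an aromatic carbon as its only change. Among the compounds with values here, no measured pair makes this exact exchange, but three measured steps at the same place bear on it, namely a number 2.2 percentage points higher from compound 1 to compound 2 (within the scatter) and a number 2 percentage points higher from compound 1 to compound 3 (within the scatter) and a number 0.2 percentage points lower from compound 2 to compound 3 (within the scatter) as the last. All three are small, so exchanging hydrogen, chloro and trifluoromethyl has shown no change beyond the scatter in these compounds. In this assay no step beyond the scatter is therefore expected, and the estimated step is a number 0.4 percentage points lower from compound 3 to compound 4 (within the scatter) in numbers. Compound 4 is estimated at 2.5% with an expected range from -3% to 8% as the likely span.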

Compound 4, percent growth inhibition at one concentration: 10.1%
Compound 4: the middle estimate sits 7.6 percentage points below what was measured; measured number above the stated range.
By their numbers in this assay, from the lowest: compounds 1, 3, 2 and 4 (each within the scatter of the next).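

In this assay, methyl on this aromatic carbon gives steps of a larger size than any seen among hydrogen, chloro and trifluoromethyl: a number 7.3 percentage points higher from compound 3 to compound 4 (within the scatter), a number 7 percentage points higher from compound 2 to compound 4 (within the scatter) and a number 9.3 percentage points higher from compound 1 to compound 4 (within the scatter). Each of these steps still lies within the scatter, so methyl cannot be separated from the other three groups at this position, and the larger size is only a hint resting on a single compound. Nothing available here explains the size of these steps.

The compounds shown leave open whether an ethyl group, a longer chain or an amine at this place would give a step beyond the scatter. They also leave open whether the size of the methyl steps would hold up in repeated measurements.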